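Hydroxy in Place of Fluoro: From Compound 2 to Compound 4

The source may report more compounds than this note shows. Statements on the series, on what has been measured and on what is new or still open speak of the compounds shown alone.

Compound 1 `COc1cc(C(=O)/C=C\Nc2ccc(-c3nc4cc(OC)c(OC)c(OC)c4s3)cc2)c(Br)c(OC)c1OC`: 6600 nM
Compound 2 `COc1cc(OC)c2sc(-c3ccc(N/C=C\C(=O)c4ccc(OC)c(F)c4)c(C)c3)nc2c1`: 14700 nM
Compound 3 `COc1cc(OC)c2sc(-c3ccc(N/C=C\C(=O)c4cc(OC)c(OC)c(OC)c4Br)cc3)nc2c1`: 10300 nM

In a functional assay on HeLa cells (Homo sapiens) for antiproliferative activity, read by sulforhodamine B assay, with a stated time of 48 h (a lower number here means a stronger inhibitor, a higher number a weaker inhibitor), compound 2 gives 14700 nM, the highest of the three numbers. Compound 3, with 10300 nM, sits within the scatter of compound 2, so no order between those two can be claimed. Among the measured compounds shown here, compound 1, which gives 6600 nM, stands beyond the scatter below compound 2 and is the only measured compound that clearly differs from it.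

Compound 4 `COc1cc(OC)c2sc(-c3ccc(N/C=C\C(=O)c4ccc(OC)c(O)c4)c(C)c3)nc2c1` is built from compound 2 by one change: hydroxy in place of fluoro on an aromatic carbon. For the measured compounds named here, the single measured step among the three compounds, a 1.6-fold higher number from compound 1 to compound 3 (0.19 log units; within the scatter), concerns a different change at a different part of the shared core and stayed within the scatter. Going by the values given here, no measured pair shows a hydroxy entering or a fluoro leaving, so the data give no direct guide to the size or direction of this step. Among the compounds with values here, the expectation therefore rests on the general quietness of the one known step, and for compound 4 a change no larger than the scatter is expected, a 1.2-fold lower number from compound 2 to compound 4 (0.09 log units; within the scatter). Compound 4 is estimated at 12000 nM, with a range from 4000 nM to 40000 nM.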

Compound 4, half-maximal inhibitory concentration: 16100 nM
Compound 4: middle estimate off by 1.3-fold (0.13 log units), on the low side; the measured number falls inside the stated range.
By their numbers in this assay, from the lowest: compounds 1, 3, 2 and 4 (each within the scatter of the next, the first and the last beyond it).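

In this assay, among the compounds shown here, this is the first measured step at this position, the aromatic carbon ortho to a methoxy group, and replacing fluoro with hydroxy gives a 1.1-fold higher number from compound 2 to compound 4 (0.04 log units; within the scatter), so compound 2 and compound 4 cannot be told apart. Hydroxy, with 1 hydrogen-bond donor and 1 hydrogen-bond acceptor, stands where fluoro, with neither, stood, yet in this one pair that structural difference does not separate the two numbers beyond the scatter. Nothing available bears on why the two numbers stay so close.

The compounds shown leave open whether an amine, a carboxylic acid or a longer chain such as ethoxy at this place would keep the number within the scatter of compound 2, since fluoro and hydroxy are the only two groups compared here. They also leave open whether the same replacement would behave alike on another aryl ketone, such as the bromo-substituted ring carrying three methoxy groups in compound 1 and compound 3.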